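The source may report more compounds than this note shows. Statements on the series, on what has been measured and on what is new or still open speak of the compounds shown alone.

Working notes on the thiourea series measured in a functional assay on MCF7 cells (Homo sapiens) for cytotoxicity, read by MTT assay; on this read-out lower numbers stand for stronger inhibition and higher numbers for weaker inhibition.

Of the compounds shown here, three have numbers so far. Compound 1 `CC(C)C[C@@H](NC(=S)Nc1cc(C(F)(F)F)cc(C(F)(F)F)c1)c1nc2ccccc2[nH]1` gives 91000 nM. Compound 2 `C[C@H](NC(=S)Nc1cc(C(F)(F)F)cc(C(F)(F)F)c1)c1nc2ccccc2[nH]1` gives 187000 nM, the highest number of the three; the gap to compound 1 lies beyond the scatter. Compound 3 `C[C@@H](NC(=S)NCc1ccccc1)c1nc2ccccc2[nH]1` gives 14300 nM, the lowest number of the set, and its distance from compound 2 is also beyond the scatter.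

Compound 4 `C[C@@H](NC(=S)Nc1cc(C(F)(F)F)cc(C(F)(F)F)c1)c1nc2ccccc2[nH]1` is not yet measured. The change from compound 2 to compound 4 is the two compounds have the same atoms and bonds and differ only in configuration as drawn: 1 of 1 stereo elements differ; a stereocentre at a saturated chain carbon is drawn S in compound 2 and R in compound 4: the two compounds have the same atoms and bonds and differ only in configuration as drawn, with the stereocentre at the saturated chain carbon drawn S in compound 2 and R in compound 4. Among the compounds with values here, no pair of measured compounds in the set differs only in configuration, so the size of such a step here is unknown.

Compound 4 is estimated at 120000 nM, with a range from 40000 nM to 350000 nM. The expected step is a 1.6-fold lower number from compound 2 to compound 4 (0.19 log units; within the scatter), a modest move toward a lower number that could fall within the scatter.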

Compound 4, half-maximal inhibitory concentration: 10300 nM
Compound 4: middle estimate off by 12-fold (1.07 log units), on the high side; the measured number lies below the stated range.
By their numbers in this assay, from the lowest: compounds 4 and 3 (each within the scatter of the next); then compound 1; then compound 2.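

In this assay, within the data shown here, configuration at the saturated chain carbon proves a strong determinant of the read-out, with an 18-fold lower number from compound 2 to compound 4 (1.26 log units; beyond the scatter), and this large gap can be tied to that single stereocentre because nothing else changes: the fact that compounds 2 and 4 differ only in the configuration as drawn The earlier compounds gave no reading of configuration, and the R form as drawn is now the one with the lower number in this pair. A second change at the same chain carbon, hydrogen in place of isopropyl, gives an 8.8-fold lower number from compound 1 to compound 4 (0.95 log units; beyond the scatter), a modest step, so the chain substituent also matters here.

As far as these compounds go, whether the same configuration effect holds with the thiourea substituent of compound 3 remains open. Also open, from the compounds shown here alone, is how a carboxylic acid or an amine on the chain at this carbon would read.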